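Swapping ethynyl for nitro: what compound 4 may show

The source may hold more compounds than are shown below. What is called first, only, known or untested is meant among the compounds shown, and "the series" means these compounds.

The values below come from a functional assay on SK-OV-3 cells (Homo sapiens) for antiproliferative activity, read by MTT assay, with a stated time of 72 h (a lower number here means a stronger inhibitor, a higher number a weaker inhibitor), and compound 4 has none yet.

- Compound 1 `O=C(CCc1cccc2c1B(O)OC2)NC1CCCCC1` gives > 100000 nM (a limit of the assay, not a number)
- Compound 2 `O=C(CCc1cccc2c1B(O)OC2)Nc1ccccc1` gives 200 nM (a measured number)
- Compound 3 `C#Cc1ccc(NC(=O)CCc2cccc3c2B(O)OC3)cc1` gives 6300 nM (a measured number)
- Compound 4 `O=C(CCc1cccc2c1B(O)OC2)Nc1ccc([N+](=O)[O-])cc1` awaits measurement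

Of the two exact numbers, compound 3 has the higher (6300 nM) and compound 2 the lower (200 nM). Compound 1 reports only a limit (> 100000 nM).

Compound 4 differs from compound 3 by carrying nitro in place of ethynyl on an aromatic carbon, para to a large group (nitro in place of ethynyl on an aromatic carbon). The closest evidence is the large step that introduced ethynyl in place of hydrogen on an aromatic carbon (a 32-fold higher number from compound 2 to compound 3 (1.50 log units; beyond the scatter)). The other large step, phenyl in place of cyclohexyl on an amide-type nitrogen (an at least 500-fold lower number from compound 1 to compound 2 (2.69 log units; beyond the scatter)), bears less directly, since compound 3 and compound 4 both keep the aromatic ring. Among the compounds with values here, no measured step replaces one substituent at this place with another, so the size remains uncertain. Compound 2 (200 nM) shows that a lower number is possible in this assay at this place, so a modest move in that direction is expected. The estimated change is a 2.5-fold lower number from compound 3 to compound 4 (0.40 log units; beyond the scatter) (an expectation only). Compound 4 is therefore expected at 2500 nM (estimated range 300 nM to 15000 nM).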

Compound 4, half-maximal inhibitory concentration: 83000 nM
For compound 4 the middle estimate is 33-fold (1.52 log units) below the measured one; the measured number lies above the stated range.
By their numbers in this assay, from the lowest: compound 2; then compound 3; then compound 4. At a limit, above all of these: compound 1.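

In this assay, the substituent on this aromatic carbon, para to a large group, matters by its identity and not only by its presence: nitro in place of ethynyl gives a 13-fold higher number from compound 3 to compound 4 (1.12 log units; beyond the scatter). Both groups move the number the same way from the hydrogen of the parent, ethynyl with a 32-fold higher number from compound 2 to compound 3 (1.50 log units; beyond the scatter) and nitro with the larger 420-fold higher number from compound 2 to compound 4 (2.62 log units; beyond the scatter), so neither substituent shown recovers the value of compound 2, 200 nM. Compound 1 alone remains at a limit of the assay rather than a number, so the series now runs from compound 2 up towards that limit: the limit of > 100000 nM in this assay, at which 1 of the 4 values shown sits.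

The compounds shown leave open whether any group on this carbon can match or improve on the plain hydrogen of compound 2, for example an amine, a methoxy group or a single fluorine atom. They also leave open whether a carboxylic acid at the same place would follow nitro and ethynyl, and whether either of those two groups would give a similar result on another carbon of the ring.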